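The source may hold more compounds than are shown below. What is called first, only, known or untested is meant among the compounds shown, and "the series" means these compounds.

Two close analogues sharing one core have been examined in a functional assay on KM12 cells (Homo sapiens) for antiproliferative activity; on this read-out lower numbers stand for stronger inhibition of growth and higher numbers for weaker inhibition of growth. Compound 1, `CCOC(=O)C[C@H]1[C@@H](O[Si](C)(C)C(C)(C)C)[C@H](n2cnc3c(NC(=O)Nc4ccccc4)ncnc32)O[C@@H]1COC(=O)NC`, gives 3.21 nM in this assay. Compound 2, `CNC(=O)NC[C@H]1O[C@@H](n2cnc3c(NC(=O)Nc4ccccc4)ncnc32)[C@H](O[Si](C)(C)C(C)(C)C)[C@@H]1CC(=O)N(C)OC`, gives 23.9 nM in this assay, which is the higher of the two numbers, and the gap between these two values lies beyond the usual scatter.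

The next compound, compound 3, `CCOC(=O)C[C@H]1[C@@H](O[Si](C)(C)C(C)(C)C)[C@H](n2cnc3c(NC(=O)Nc4ccccc4)ncnc32)O[C@@H]1CNC(=O)NC`, is not yet measured. It differs from compound 2 in one place: ethoxy in place of methoxy(methyl)amino on a carbonyl carbon. Going by the values given here, the ethoxy group that enters is the one carried by compound 1, while the methylurea of compound 2 is retained.

A step in this assay from compound 2 to compound 3 of moderate size towards a lower number is expected, a 3.0-fold lower number from compound 2 to compound 3 (0.48 log units; beyond the scatter), because compound 1 gives 3.21 nM. Compound 3 is therefore estimated at 8 nM, with a range from 2.5 nM to 30 nM.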

Compound 3, concentration for 50% growth inhibition: 3.95 nM
Beside the measured number, compound 3's estimate is 2.0-fold (0.31 log units) above it; the measured number falls inside the stated range.
By their numbers in this assay, from the lowest: compounds 1 and 3 (each within the scatter of the next); then compound 2.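

With the (methylcarbamoyl)amino group held constant, this assay shows a 6.1-fold lower number from compound 2 to compound 3 (0.78 log units; beyond the scatter) when ethoxy replaces methoxy(methyl)amino on the carbonyl carbon, so this substituent alone shifts the number beyond the scatter. At the saturated chain carbon bound to a saturated ring carbon, with ethoxycarbonyl held constant, (methylcarbamoyl)amino in place of (methylcarbamoyl)oxy gives a 1.2-fold higher number from compound 1 to compound 3 (0.09 log units; within the scatter) and this step stays within the scatter. Going by these compounds alone, of these two single changes, only the one on the carbonyl carbon separates the compounds on this read-out. Nothing in the data shown accounts for the size of that step. The compounds shown leave open how a carboxylic acid, a methoxy group or a dimethylamino group on this carbonyl carbon would compare with ethoxy. They also leave open whether replacing methoxy(methyl)amino with ethoxy gives a similar step when (methylcarbamoyl)oxy is present.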